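Stability in liver microsomes: from compound 3 toward compound 4

The compounds below may be only part of what the source reports. "The series", "measured", "known", "first", "only" and "open" are said of these compounds alone.

Three compounds that share an amide linked through a benzylic carbon to a sulfonyl-bearing ring have been tested in an ADME assay on microsomes from liver (Homo sapiens) for metabolic stability, read by LC-MS, with a stated time of 30 min, tested at 1 uM; on this read-out higher numbers stand for a more stable compound and lower numbers for a less stable compound. Compound 1 `O=C(NCc1ccc(S(=O)(=O)c2cc(F)cc(F)c2)cc1)c1cc2ccncc2o1` gives 77%. Compound 2 `O=C(NCc1ccc(S(=O)(=O)N2CCCCC2)cc1)c1ccn2cncc2c1` gives 54%. Compound 3 `O=C(NCc1ccc(S(=O)(=O)c2ccccc2)cc1)c1cc2ccncc2s1` gives 48%. On these numbers compound 3 has the lowest value; its nearest neighbour is compound 2, whose value lies within the scatter, while compound 1 stands well beyond the scatter above it.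

Compound 4 `O=C(NCc1ccc(S(=O)(=O)c2ccccc2)cc1)c1ccc2nccn2c1` has not yet been measured. It differs from compound 3 in a single place: a group of 9 heavy atoms (7 carbon, 2 nitrogen; one five-membered aromatic ring with 2 hetero atoms, one six-membered aromatic ring with 1 hetero atom) in place of a group of 9 heavy atoms (7 carbon, 1 nitrogen, 1 sulfur; one five-membered aromatic ring with 1 hetero atom, one six-membered aromatic ring with 1 hetero atom), on a carbonyl carbon. The carbonyl carbon and the amide-type nitrogen that carries the benzylic chain are untouched; only the aromatic group attached to that carbonyl is exchanged.

For the measured compounds named here, no measured pair in this set shows this exact exchange, so the direction of the step must be guessed from the whole set. Compound 2, whose value is 54%, carries a carbonyl-attached group of the same kind of ring count and sits close to compound 3. A small upward move is therefore expected, but one that stays within the scatter: the expected step from compound 3 to compound 4 is a number 7 percentage points higher from compound 3 to compound 4 (within the scatter). Compound 4 is expected to give about 55% in this assay, most likely between 35% and 75%.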

Compound 4, percent of the compound remaining: 77%
The estimate for compound 4 lay 22 percentage points below the measured number; the measured number lies above the stated range.
By their numbers in this assay, from the lowest: compounds 3 and 2 (each within the scatter of the next); then compounds 1 and 4 (each within the scatter of the next).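

In this assay, the set now holds its first comparison of two compounds that differ in one place, and it reads a number 29 percentage points higher from compound 3 to compound 4 (beyond the scatter) with the rest of the molecule untouched. For the compounds shown here, this shows that the aromatic group on the carbonyl carbon can shift this read-out by more than the usual scatter, which the earlier compounds could not show because each differed from the others in more than one place. The step comes with no change in the counts of heavy atoms, hydrogen-bond donors or hydrogen-bond acceptors, or in net charge: a sulfur leaves, a nitrogen enters, and the five-membered aromatic ring now has 2 hetero atoms instead of 1, but nothing at hand explains why the number moves.

As far as these compounds go, whether the same exchange would give a step of similar size alongside the sulfonyl-bearing parts of compound 1 or compound 2 remains open. Also open, from the compounds shown here alone, is how this read-out would respond if the aromatic group on the carbonyl carbon carried a further substituent, such as an amine or a carboxylic acid.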